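Chloro on the five-membered ring of the sulfonamide series

This account rests on a few compounds, and the source may have more. Where it says the series, first, only, none or still open, it means among the compounds named here.

Of the compounds shown here, three have been measured in a functional assay on MC-38 cells (Mus musculus) for antiproliferative activity, read by colorimetric assay and MTT assay; a higher number here means a weaker inhibitor, a lower number a stronger inhibitor. Compound 1 `COc1ccc(S(=O)(=O)Nc2cccc3cc[nH]c23)cc1` gives 1.5 ug/mL. Compound 2 `COc1ccc(S(=O)(=O)Nc2ccc(Cl)c3cc[nH]c23)cc1` carries chloro in place of hydrogen on an aromatic carbon and gives 0.65 ug/mL, so that a 2.3-fold lower number from compound 1 to compound 2 (0.36 log units; beyond the scatter). Compound 3 `N#Cc1ccc(S(=O)(=O)Nc2ccc(Cl)c3cc[nH]c23)cc1` gives 0.22 ug/mL; a 3.0-fold lower number from compound 2 to compound 3 (0.47 log units; beyond the scatter). Compound 3 thus holds the lowest number of the three in this assay, with compounds 2 and 1 both beyond the scatter above it. The difference between the core of compound 1 and the core of compound 3 is not broken down here.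

Compound 4 `N#Cc1ccc(S(=O)(=O)Nc2ccc(Cl)c3c(Cl)c[nH]c23)cc1` is not yet measured. It differs from compound 3 by chloro in place of hydrogen on an aromatic carbon. This is the same kind of change as that from compound 1 to compound 2, but not the same: in compound 2 the chloro enters on a six-membered aromatic ring of carbon only, ortho to a fused ring, meta to a fused ring and para to a large group, whereas in compound 4 it enters on a five-membered aromatic ring with one nitrogen, two ring bonds from the ring nitrogen. Among the measured compounds shown here, the only measured precedent is therefore indirect. Because a 2.3-fold lower number from compound 1 to compound 2 (0.36 log units; beyond the scatter), a step of similar direction is expected in this assay, but the different place argues for a wide margin. Compound 4 is estimated at 0.15 ug/mL, between 0.06 ug/mL and 0.45 ug/mL, which means an expected 1.5-fold lower number from compound 3 to compound 4 (0.17 log units; within the scatter).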

Compound 4, half-maximal inhibitory concentration: 0.12 ug/mL
Beside the measured number, compound 4's estimate is 1.3-fold (0.10 log units) above it, and the stated range covers the measured number.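

In this assay the chloro entering on the five-membered aromatic ring, two ring bonds from the ring nitrogen, gives a 1.8-fold lower number from compound 3 to compound 4 (0.26 log units; within the scatter) and so does not by itself separate compound 4 from compound 3. Set beside the earlier chloro step, which lies on a six-membered aromatic ring of carbon only, the change reads alike on the two cores: the same change on two cores in this assay, a 2.3-fold lower number (0.36 log units; beyond the scatter) from compound 1 to compound 2 and a 1.8-fold lower number (0.26 log units; within the scatter) from compound 3 to compound 4, 1.3-fold (0.10 log units) apart, within the scatter of two such steps

Among the compounds shown here, this agreement shows only that two chloro steps are compatible in size and does not establish a transferable effect, since one step lies beyond the scatter and the other within it, and the two differ in both the place of the chloro and the surrounding core.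

Open, as far as these compounds go, is how a methyl, a bromo or a carboxylic acid in place of the chloro on the five-membered aromatic ring of compound 4 would read in this assay. Also open, from the compounds shown here alone, is how the same ring chloro would read with methoxy in place of cyano, which would separate the place of the chloro from the rest of the core.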